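Compound 2 to compound 3: nitro gives way to fluoro

The source may hold more compounds than are shown below. What is called first, only, known or untested is meant among the compounds shown, and "the series" means these compounds.

Compound 1 `O=C(O)c1cncc(-n2cc(CO[C@H]3O[C@H](CO)[C@@H](O)[C@H](O)[C@@H]3O)nn2)c1`: > 3000 ug/mL (a limit)
Compound 2 `O=[N+]([O-])c1ccc(-n2cc(CO[C@H]3O[C@H](CO)[C@@H](O)[C@H](O)[C@@H]3O)nn2)cc1`: 2600 ug/mL

For the measured compounds named here, in a physicochemical assay for solubility, read by LC-MS, using the shake flask method, measured as thermodynamic solubility, with a stated time of 24 h, at pH 6.5 (on this read-out lower numbers stand for lower solubility and higher numbers for higher solubility), compound 2 gives 2600 ug/mL, the only actual number available. Compound 1 reports only a limit, (the limit of > 3000 ug/mL in this assay, at which 1 of the 2 values shown sits).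

The next compound, compound 3 `OC[C@H]1O[C@H](OCc2cn(-c3ccc(F)cc3)nn2)[C@@H](O)[C@@H](O)[C@@H]1O`, carries fluoro in place of nitro on an aromatic carbon, para to a large group, or 4-nitrophenyl to 4-fluorophenyl: fluoro in place of nitro on an aromatic carbon. Going by the values given here, no measured step covers this change directly. Among the compounds with values here, the one measured step is an at least 1.1-fold lower number from compound 1 to compound 2 (0.06 log units; that floor lies within the scatter), with 4-nitrophenyl in place of 5-carboxypyridin-3-yl on an aromatic nitrogen. Since that exchange of a whole group, from compound 1 to compound 2, shows no step beyond the scatter, the smaller exchange on compound 2 is expected to show none in this assay either, and no direction can be drawn from the data. The estimated change is a 1.1-fold higher number from compound 2 to compound 3 (0.03 log units; within the scatter). Compound 3 is expected at 2800 ug/mL, with an estimated range from 1300 ug/mL to 4500 ug/mL.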

Compound 3, solubility: > 3000 ug/mL
Compound 3: only a limit was reported; the forecaster's own chance of this, stated with the estimate: 35%; middle value at least 1.0-fold (0.02 log units) from the limit.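

In this assay the exchange of nitro for fluoro on an aromatic carbon, para to a large group, gives an at least 1.1-fold higher number from compound 2 to compound 3 (0.06 log units; that floor lies within the scatter), the first step shown that alters this position on the aromatic ring while leaving the ring itself in place. For compound 3 the reading is a limit, > 3000 ug/mL, and not a number. The step therefore gives only a floor and no true size, so replacing the nitro group with fluoro is not shown to change the reading beyond the scatter, and compound 2 remains the only compound with an actual number, while the others share a ceiling: the limit of > 3000 ug/mL in this assay, at which 2 of the 3 values shown sit.

The step between compound 1 and compound 3 joins two limits and cannot be read, which leaves open how the 4-fluorophenyl and 5-carboxypyridin-3-yl groups compare in this assay. Also open, on these data alone, is whether an amine, a methoxy group or a longer chain at this same place on the ring would give an actual number or another limit.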